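Compound 2 to compound 4: an aryl swap on nitrogen

The source may hold more compounds than are shown below. What is called first, only, known or untested is meant among the compounds shown, and "the series" means these compounds.

In a functional assay on A549 cells (Homo sapiens) for inhibition, read by sulforhodamine B assay, with a stated time of 48 h, tested at 50 uM (on this read-out higher numbers stand for more inhibition of growth at the one concentration tested and lower numbers for less inhibition of growth), compound 2 `COc1ccc([C@@H]2C/C(=N/OCc3cn(-c4ccc(O)cc4)nn3)c3cc(CC=C(C)C)c(OC)cc3O2)cc1` gives 52%, which is within the scatter of compound 1 `CCCOc1ccc([C@@H]2CC(=O)c3cc(CC=C(C)C)c(OC)cc3O2)cc1` at 43%. Compound 3 `CCCCOc1ccc([C@@H]2CC(=O)c3cc(CC=C(C)C)c(OC)cc3O2)cc1` gives 37%, lower than compound 2 by more than the scatter.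

Compound 4 `COc1ccc([C@@H]2C/C(=N/OCc3cn(-c4ccccc4CO)nn3)c3cc(CC=C(C)C)c(OC)cc3O2)cc1` carries one change relative to compound 2: 2-(hydroxymethyl)phenyl in place of 4-hydroxyphenyl on an aromatic nitrogen. In words, 2-(hydroxymethyl)phenyl replaces 4-hydroxyphenyl on an aromatic nitrogen.

Among the compounds with values here, the only measured step, a number 6 percentage points lower from compound 1 to compound 3 (within the scatter), is a small one, and it lies on a saturated chain, away from this nitrogen substituent. Within the data shown here, no measured pair varies the group at this place, so the data give neither a size nor a direction for the swap. No step beyond the scatter is therefore expected in this assay.

The expected change is small, estimated as a number 3 percentage points lower from compound 2 to compound 4 (within the scatter). Compound 4 is expected at 49%, with an estimated range of 35% to 62%.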

Compound 4, percent growth inhibition at one concentration: 100%
Beside the measured number, compound 4's estimate is 51 percentage points below it, and the stated range ends below it.
By their numbers in this assay, from the lowest: compounds 3, 1 and 2 (each within the scatter of the next, the first and the last beyond it); then compound 4.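

In this assay, the aryl group on an aromatic nitrogen of the five-membered aromatic ring proves to be a highly sensitive place in the series: 2-(hydroxymethyl)phenyl in place of 4-hydroxyphenyl gives a number 48 percentage points higher from compound 2 to compound 4 (beyond the scatter). The two groups have the same counts of hydrogen-bond donors and acceptors and the same six-membered aromatic ring of carbon only, so these counts stay unchanged across the step. No available evidence bears on what lies behind this step.

This single pair alters both the oxygen-bearing substituent and where it stands on the phenyl ring, and it leaves the contribution of each unresolved. Also open, from the compounds shown here alone, is how a plain phenyl would read on this nitrogen, or an aminomethyl group or a carboxylic acid in place of the hydroxymethyl.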